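Methoxycarbonyl in Place of Fluoro on the Benzyl Ring

A few compounds are considered here, and "the series" means these few. Any claim that something is new, unique, unknown or untested is made for them only; others in the source may bear on it.

Compound 1 `Cc1c(Cc2ccccc2)c(=O)oc2cc(OCC(O)CNCc3ccccc3)ccc12`: in an ADME assay on A549 cells (Homo sapiens) for cytotoxicity, read by CellTiter-Glo (on this read-out lower numbers stand for higher toxicity in this test and higher numbers for lower toxicity in this test), compound 1 reaches only the limit > 100000 nM.
Compound 2 `Cc1ccc2nc(NCC(O)COc3ccc4c(C)c(Cc5ccccc5)c(=O)oc4c3)sc2c1`: in this assay compound 2 likewise reaches only the limit > 100000 nM.
Compound 3 `Cc1c(Cc2ccc(F)cc2)c(=O)oc2cc(OCC(O)CN3CCC(C(N)=O)CC3)ccc12`: in this assay compound 3 gives 89300 nM.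

Among the compounds with values here, compound 3 therefore stands as the only real number among the three; the other two are limits, as recorded in the limit of > 100000 nM in this assay, at which 2 of the 3 values shown sit. Within the data shown here, the single step between measured compounds, a step that the two limits leave unreadable from compound 1 to compound 2, cannot be read. Compound 4 `COC(=O)c1ccc(Cc2c(C)c3ccc(OCC(O)CN4CCC(C(N)=O)CC4)cc3oc2=O)cc1` differs from compound 3 by methoxycarbonyl in place of fluoro on an aromatic carbon. Among the measured compounds shown here, no measured step touches this change; the one step known lies at another place and has no readable size. With nothing pointing to a shift beyond the scatter, compound 4 is expected near 95000 nM, between 40000 nM and 200000 nM, the expected step being a 1.1-fold higher number from compound 3 to compound 4 (0.03 log units; within the scatter).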

Compound 4, half-maximal cytotoxic concentration: > 100000 nM
Compound 4: only a limit was reported; the forecaster's own chance of this, stated with the estimate: 45%; at least 1.0-fold (0.02 log units) between middle value and limit.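

Within the data shown here, at the position para to a large group on the benzyl ring, methoxycarbonyl in place of fluoro gives in this assay an at least 1.1-fold higher number from compound 3 to compound 4 (0.04 log units; that floor lies within the scatter), the first step at this place that can be read, if only as a floor. The four heavy atoms of methoxycarbonyl, with its two hydrogen-bond acceptors, bring no lower number here, though the true size of the step stays hidden. Compound 4 adds one more limit to the series: the limit of > 100000 nM in this assay, at which 3 of the 4 values shown sit.

On these data alone, whether a carboxylic acid, a nitrile or an amine at this position would also stay at this limit remains open. So does whether methoxycarbonyl would read the same with the side chain of compound 1.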